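Swapping Phenoxy for Trifluoromethoxy on a Shared Core

This account rests on a few compounds, and the source may have more. Where it says the series, first, only, none or still open, it means among the compounds named here.

Of the compounds shown here, three built on one shared core have been tested in a functional assay on MIA PaCa-2 cells (Homo sapiens) for cytotoxicity, read by MTT assay, with a stated time of 72 h; a higher number here means a weaker inhibitor, a lower number a stronger inhibitor. Compound 1, `O=C1C(Nc2ccc(Oc3ccccc3)cc2)=CC(=O)c2ncncc21`, gives 3700 nM. Compound 3, `O=C1C(NCc2ccc(F)cc2)=CC(=O)c2ncncc21`, gives 1700 nM, so of the two numbers measured, compound 1 stands as the higher, and its gap to compound 3 lies beyond the usual scatter of repeated measurements. Compound 2, `O=C1C(Nc2cccc(B(O)O)c2)=CC(=O)c2ncncc21`, yields only a limit of the assay and not a number, > 10000 nM. That result is the limit of > 10000 nM in this assay, at which 1 of the 3 values shown sits.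

The compound now in question is compound 4, `O=C1C(Nc2ccc(OC(F)(F)F)cc2)=CC(=O)c2ncncc21`. It differs from compound 1 in one place: trifluoromethyl in place of phenyl on an oxygen on an aromatic ring. Among the compounds with values here, no pair of measured compounds differs from each other in just this way, so there is no measured step of this kind to lean on, and the starting point is simply compound 1 at 3700 nM. In this assay the expected step is a 1.2-fold lower number from compound 1 to compound 4 (0.09 log units; within the scatter), a shift small enough to fall within the usual scatter, with no confident direction. Compound 4 is therefore expected to give about 3000 nM, within a range from 1000 nM to 9000 nM.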

Compound 4, half-maximal inhibitory concentration: 1400 nM
Beside the measured number, compound 4's estimate is 2.1-fold (0.33 log units) above it; the measured number falls inside the stated range.
By their numbers in this assay, from the lowest: compounds 4 and 3 (each within the scatter of the next); then compound 1. At a limit, above all of these: compound 2.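

In this assay, within the data shown here, replacing phenoxy with trifluoromethoxy on the shared core gives a 2.6-fold lower number from compound 1 to compound 4 (0.42 log units; beyond the scatter) and provides the first measured step at this place, showing that the group on this oxygen can move the number by more than ordinary repeat-to-repeat variation. The phenyl ring is therefore not needed on this oxygen to keep the cytotoxic effect in these cells, since the smaller trifluoromethyl, which has no ring, gives a modestly stronger result. Nothing in the data shown explains why this change moves the number.

With only one replacement on this oxygen, the loss of the ring cannot be told apart from the arrival of the fluorine atoms, and a plain methyl or a benzyl on the same oxygen would help to separate the two. Compound 2 and compound 3 differ from compound 1 in more than one place, so the compounds shown also leave open whether the same swap would give a similar step with a different group elsewhere on the shared core.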